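Swapping 4-fluorophenyl for 3,4,5-trimethoxyphenyl in compound 3

A few compounds are considered here, and "the series" means these few. Any claim that something is new, unique, unknown or untested is made for them only; others in the source may bear on it.

Of the compounds shown here, three have been measured in a functional assay on A549 cells (Homo sapiens) for inhibition, read by MTT assay, with a stated time of 48 h (on this read-out higher numbers stand for weaker inhibition of growth and lower numbers for stronger inhibition of growth), so far.

Compound 1 `Cn1cc(C2CC(c3ccc(F)cc3)=NN2C(=O)c2cccnc2)c2cc(Br)ccc21` gives 1380 nM
Compound 2 `COc1ccc(C2=NN(C(=O)c3ccncc3)C(c3cn(C)c4ccc(Br)cc34)C2)cc1OC` gives 4250 nM
Compound 3 `COc1ccc2c(c1)c(C1CC(c3ccc(F)cc3)=NN1C(=O)c1ccc(OC)nc1)cn2C` gives 710 nM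

Compound 3 and compound 1 lie within the usual scatter of each other, so the two cannot be ranked. Compound 2 has a number beyond the scatter from compound 3, and it is the higher one, which means weaker inhibition of growth.

The next compound is compound 4 `COc1ccc2c(c1)c(C1CC(c3cc(OC)c(OC)c(OC)c3)=NN1C(=O)c1ccc(OC)nc1)cn2C`, which matches compound 3 except at one place. On a carbon with a double bond to nitrogen, 3,4,5-trimethoxyphenyl stands in place of 4-fluorophenyl (3,4,5-trimethoxyphenyl in place of 4-fluorophenyl on a carbon with a double bond to nitrogen).

Going by the values given here, no two measured compounds differ in one place only, so no earlier step shows what such a swap does. Among the compounds with values here, compound 2, the one measured compound with methoxy groups on the phenyl at that carbon, gives 4250 nM, but it also differs from compound 3 elsewhere and is only a weak guide. In this assay the expected result is therefore no clear change, with the estimated 1.1-fold higher number from compound 3 to compound 4 (0.05 log units; within the scatter) staying within the scatter. So little evidence calls for a wide range. The estimate for compound 4 is 800 nM (expected range 200 nM to 3000 nM).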

Compound 4, concentration for 50% growth inhibition: > 10000 nM
Compound 4: a limit, no number; the forecaster's own chance of this, stated with the estimate: 3%; middle value at least 12-fold (1.09 log units) away from the limit.
By their numbers in this assay, from the lowest: compounds 3 and 1 (each within the scatter of the next); then compound 2. At a limit, above all of these: compound 4.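

In this assay, replacing 4-fluorophenyl with 3,4,5-trimethoxyphenyl on the carbon with a double bond to nitrogen gives an at least 14-fold higher number from compound 3 to compound 4 (1.14 log units; beyond the scatter), which means much weaker inhibition of growth. Compound 4 gives > 10000 nM, which is a limit of the assay and not a number. No earlier pair differed in one place only, so this is the first direct sign that the group at this position can by itself decide whether growth inhibition is seen within the tested range, although the true size of the step remains unknown: the limit of > 10000 nM in this assay, at which 1 of the 4 values shown sits.

A single swap cannot show which part of the change matters, whether the loss of the fluorine or the arrival of the methoxy groups, so a plain phenyl or a phenyl carrying a single methoxy group would help separate the two. Going by these compounds, it is also open whether other groups at this position, such as a phenyl carrying an amine, would be tolerated, and whether the same swap has a similar effect when the rest of the molecule differs.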